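The source may report more compounds than this note shows. Statements on the series, on what has been measured and on what is new or still open speak of the compounds shown alone.

Three compounds share one core and differ only in the ring attached to the amide carbonyl: compound 1 `COc1ccc(C(=O)Nc2cccc(-c3oc4cc(-c5ccc(F)cc5)ccc4c(=O)c3O)c2)cc1`, compound 2 `Cc1ccc(C(=O)Nc2cccc(-c3oc4cc(-c5ccc(F)cc5)ccc4c(=O)c3O)c2)cc1` and compound 3 `Cc1cc(C(=O)Nc2cccc(-c3oc4cc(-c5ccc(F)cc5)ccc4c(=O)c3O)c2)ccc1F`. In a functional assay on MCF7 cells (Homo sapiens) for antiproliferative activity, read by CCK-8 assay, with a stated time of 72 h (a higher number here means a weaker inhibitor, a lower number a stronger inhibitor), compound 1 gives 6250 nM, compound 2 gives 2400 nM and compound 3 gives 7710 nM, the highest of the three numbers, though its gap to compound 1 stays within the scatter, while a 3.2-fold higher number from compound 2 to compound 3 (0.51 log units; beyond the scatter). Compound 4 `N#Cc1ccc(C(=O)Nc2cccc(-c3oc4cc(-c5ccc(F)cc5)ccc4c(=O)c3O)c2)cc1` carries the next change: 4-cyanophenyl in place of 4-fluoro-3-methylphenyl on a carbonyl carbon. Only the earlier swaps on this same ring bear on it, and they were modest at most: a 2.6-fold lower number from compound 1 to compound 2 (0.42 log units; beyond the scatter) and a 1.2-fold higher number from compound 1 to compound 3 (0.09 log units; within the scatter). From the compounds shown here alone, a nitrile here is untested, so a step of similar size in either direction, or none beyond the scatter, is expected. For compound 4 the estimate is 5000 nM, with a range from 1800 nM to 14000 nM. That estimate means a 1.5-fold lower number from compound 3 to compound 4 (0.19 log units; within the scatter) is expected.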

Compound 4, half-maximal inhibitory concentration: 2660 nM
Compound 4: the middle estimate sits 1.9-fold (0.27 log units) above what was measured; measured number inside the range.
By their numbers in this assay, from the lowest: compounds 2 and 4 (each within the scatter of the next); then compounds 1 and 3 (each within the scatter of the next).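

Swapping in 4-cyanophenyl recovers what 4-fluoro-3-methylphenyl lost (a 2.9-fold lower number from compound 3 to compound 4 (0.46 log units; beyond the scatter)) and also improves on 4-methoxyphenyl (a 2.3-fold lower number from compound 1 to compound 4 (0.37 log units; beyond the scatter)). The nitrile and the methyl cannot be told apart at this position (a 1.1-fold higher number from compound 2 to compound 4 (0.04 log units; within the scatter)), so this ring has now given two equally good groups that differ in kind, not just one. Nothing available here explains why these groups rank as they do. From the compounds shown here alone, whether an amine or a carboxylic acid on this ring would hold this level remains open. So does the effect of a longer chain in that place.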